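Series notes: from compound 3 to compound 4

A few compounds are considered here, and "the series" means these few. Any claim that something is new, unique, unknown or untested is made for them only; others in the source may bear on it.

Measured so far in an ADME assay on the whole organism (Rattus norvegicus) for pharmacokinetics, using cassette dosing, at a dose of 1 mg/kg by the oral route; on this read-out lower numbers stand for lower oral bioavailability and higher numbers for higher oral bioavailability

- compound 1 `CC(C)Oc1ccc(/N=c2\[nH]c(=O)n(C[C@@H](C)C(=O)O)c(=O)n2Cc2ccc(Cl)cc2)cc1Cl` gives 108%
- compound 2 `Cc1cc(/N=c2\[nH]c(=O)n(C[C@H](C)C(=O)O)c(=O)n2Cc2ccc(Cl)cc2)ccc1OC(C)C` gives 102%
- compound 3 `C[C@@H](Cn1c(=O)[nH]/c(=N\c2ccc(Oc3cncc(F)c3)cc2)n(Cc2ccc(Cl)cc2)c1=O)C(=O)O` gives 74.3%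

Compound 3 stands lowest of the three, and the gaps up to compound 2 and to compound 1 both lie beyond the scatter. Those two sit within the scatter of each other.

Next is compound 4 `C[C@@H](Cn1c(=O)[nH]/c(=N\c2ccc(Oc3ccccn3)cc2)n(Cc2ccc(Cl)cc2)c1=O)C(=O)O`, with pyridin-2-yl in place of 5-fluoropyridin-3-yl on an oxygen on an aromatic ring. For the measured compounds named here, no pair of measured compounds differs in one place only, so the series offers no direct precedent for this change in this assay. The expectation therefore starts from compound 3 at 74.3% and favours no clear direction. The expected result is a number 4.3 percentage points lower from compound 3 to compound 4 (within the scatter), a step not beyond the scatter. The estimate for compound 4 is 70%, with an expected range from 42% to 98%.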

Compound 4, oral bioavailability: 52.8%
Compound 4: middle estimate off by 17.2 percentage points, on the high side; the measured number falls inside the stated range.
By their numbers in this assay, from the lowest: compound 4; then compound 3; then compounds 2 and 1 (each within the scatter of the next).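

In this assay the series now has its first step at a single place: a number 21.5 percentage points lower from compound 3 to compound 4 (beyond the scatter). This shows that the group on an oxygen on an aromatic ring can move oral bioavailability beyond the scatter, even when one pyridine ring replaces another and the counted hydrogen-bond donors and acceptors stay the same. No measurement shown accounts for this step.

The change removes the fluorine and also alters the point of attachment on the pyridine ring, so the two contributions remain unseparated. Going by these compounds, a plain pyridin-3-yl or a phenyl group on the same oxygen would separate them, and it remains open whether either would stand closer to compound 3 or to compound 4.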